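The compounds below may be only part of what the source reports. "The series", "measured", "known", "first", "only" and "open" are said of these compounds alone.

Compound 1, with the structure `O=C(CSc1nc(Nc2ccccc2)c2ccccc2n1)Nc1ccccc1Cl`, is one of three related compounds tested in a functional assay on PC-3 cells (Homo sapiens) for inhibition, read by MTT assay, with a stated time of 72 h; a lower number here means a stronger inhibitor, a higher number a weaker inhibitor. In this assay compound 1 gives 14600 nM, which is the highest of the three numbers, though none of the three is separated from another by more than the scatter. Compound 2 `O=C(CSc1nc(Nc2ccccc2)c2ccccc2n1)Nc1cccc([N+](=O)[O-])c1` gives 11800 nM, and compound 3 `CCc1cccc(NC(=O)CSc2nc(Nc3ccccc3)c3ccccc3n2)c1` gives 11000 nM. The step of a 1.2-fold lower number from compound 1 to compound 2 (0.09 log units; within the scatter) and the step of a 1.3-fold lower number from compound 1 to compound 3 (0.12 log units; within the scatter) are both within the scatter, as is a 1.1-fold lower number from compound 2 to compound 3 (0.03 log units; within the scatter). So far, then, exchanging the ring on the amide-type nitrogen has not moved the number beyond what repeated measurements of one compound would show.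

Compound 4 `O=C(CSc1nc(Nc2ccccc2)c2ccccc2n1)Nc1ccc(Cl)cc1` has not yet been measured. It differs from compound 1 in one place: 4-chlorophenyl in place of 2-chlorophenyl on an amide-type nitrogen. Among the compounds with values here, the steps that bear on this change are those from compound 1 to compound 2 and from compound 1 to compound 3, each of which replaced the same 2-chlorophenyl with a different ring, and each stayed within the scatter. Within the data shown here, nothing among the measured compounds suggests that exchanging 2-chlorophenyl for 4-chlorophenyl would behave differently. The expected step is therefore a 1.1-fold lower number from compound 1 to compound 4 (0.05 log units; within the scatter), nothing beyond the scatter. Compound 4 is estimated at 13000 nM, with a range from 5000 nM to 35000 nM.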

Compound 4, half-maximal inhibitory concentration: 12900 nM
For compound 4 the middle estimate is 1.0-fold (0.00 log units) above the measured one; measured number inside the range.
By their numbers in this assay, from the lowest: compounds 3, 2, 4 and 1 (each within the scatter of the next).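

In this assay, 4-chlorophenyl and 2-chlorophenyl on the amide-type nitrogen hold the same atoms joined differently, and the exchange gives only a small step (a 1.1-fold lower number from compound 1 to compound 4 (0.05 log units; within the scatter)), so among these compounds this rearrangement of the same atoms does not separate the two. Compound 4 also stays within the scatter of the two compounds carrying other rings at this place (a 1.2-fold higher number from compound 3 to compound 4 (0.07 log units; within the scatter); a 1.1-fold higher number from compound 2 to compound 4 (0.04 log units; within the scatter)), which means that all four groups shown here, including two arrangements of one chlorophenyl, give numbers that cannot be told apart, and none of the four goes against this. No evidence on the cause of this sameness is at hand.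

On these data alone, all four groups at this place are substituted aromatic rings, so it remains open whether a cyclohexyl ring, or a ring bearing a carboxylic acid or an aminomethyl group, would give a number beyond the scatter. The core stays the same across the four compounds, which leaves open how a change there, such as a longer chain in place of the link to the amide, would read in this assay.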